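From hydroxy to methoxy: compound 2 and compound 3

A few compounds are considered here, and "the series" means these few. Any claim that something is new, unique, unknown or untested is made for them only; others in the source may bear on it.

Measured in a functional assay on Bel-7402 cells (Homo sapiens) for antiproliferative activity, read by MTT assay, with a stated time of 48 h; on this read-out lower numbers stand for stronger inhibition of growth and higher numbers for weaker inhibition of growth:
- Compound 1 `COc1cc(/C=C2\Cc3cc(OC)c(OC)c(OC)c3C2=O)cc(OC)c1OC` gives > 10000 nM
- Compound 2 `COc1cc2c(cc1O)C(=O)/C(=C/c1cc(OC)c(OC)c(OC)c1)C2` gives > 10000 nM

Compound 2 stands at > 10000 nM, which is a limit of the assay and not a number. Compound 1 likewise reaches only a limit, > 10000 nM, so the record so far is the limit of > 10000 nM in this assay, at which 2 of the 2 values shown sit.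

Compound 3 `COc1cc2c(cc1OC)C(=O)/C(=C/c1cc(OC)c(OC)c(OC)c1)C2` differs from compound 2 by methyl in place of hydrogen on an oxygen on an aromatic ring, in words hydroxy to methoxy, with methyl in place of hydrogen on an oxygen on an aromatic ring. For the measured compounds named here, no step between measured compounds is available to size this change. Since compound 2 gives > 10000 nM as its limit, compound 3 is expected to show no large gain in this assay, and most likely no change beyond the scatter. The estimated change is a step that the limit leaves unreadable from compound 2 to compound 3. For compound 3 the estimate is 12000 nM, with an expected range from 3000 nM to 40000 nM.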

Compound 3, concentration for 50% growth inhibition: > 10000 nM
Compound 3: no number, only a limit (the forecaster's own chance of this, stated with the estimate: 70%); the middle value lies beyond the limit too.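

Compound 3 stands at the limit of > 10000 nM in this assay and gives no number. For the compounds shown here, no step from compound 1 or compound 2 to compound 3 can be read, with all three compounds at one limit: the limit of > 10000 nM in this assay, at which 3 of the 3 values shown sit. The compounds shown leave open whether hydroxy to methoxy changes growth inhibition at all.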